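The compounds below may be only part of what the source reports. "The series", "measured", "known", "first", "only" and "open" are said of these compounds alone.

Working notes on the series.

Compound 3 `COCCNc1ncc(C(Oc2ccc3cc(Br)ccc3c2)c2ccc(Cl)cc2)s1` is the reference point here. In an ADME assay on HepG2 2.2.15 cells (Homo sapiens) for cytotoxicity (on this read-out higher numbers stand for lower toxicity in this test and lower numbers for higher toxicity in this test), compound 3 returns "not toxic" (no number reported), so no single number is available for it. Two other members of the series give the only further context. Compound 1 `CC(C)(C)OC(=O)Nc1ncc(C(Oc2ccc(Br)cc2)c2ccc(Cl)cc2)s1` sits in this assay at > 50000 nM, which is a limit of the assay and not a number. Compound 2 `Cc1ccc(COC(c2ccccc2)c2cnc(NC(=O)c3cccs3)s2)cc1` returns in this assay "not toxic" (no number reported). Within the data shown here, with the limit of > 50000 nM in this assay, at which 1 of the 3 values shown sits, and two entries without a figure, no step between measured compounds can be computed, and compound 3 stands among values that all point to low toxicity without any being a fixed figure.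

Compound 4 `O=S(=O)(Nc1ncc(C(Oc2ccc3cc(Br)ccc3c2)c2ccc(Cl)cc2)s1)c1ccccc1` differs from compound 3 in one place: phenylsulfonyl in place of 2-methoxyethyl on a nitrogen on an aromatic ring. Among the measured compounds shown here, no measured step covers this change, and none of the three values shown can say whether it moves the read-out beyond the scatter in either direction. Given that every entry so far is a limit or a "not toxic" note, the expectation for compound 4 in this assay is that it also lands at or near the upper limit, with no change beyond the scatter expected relative to the series as a whole. Compound 4 is therefore estimated at 45000 nM, with a range from 12000 nM to 100000 nM, and it is likely that only a limit will be reported.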

Compound 4, half-maximal cytotoxic concentration: > 50000 nM
Compound 4 was reported as a limit; the forecaster's own chance of this, stated with the estimate: 65%; middle value at least 1.1-fold (0.04 log units) away from the limit.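

In this assay compound 4 gives > 50000 nM, which is a limit of the assay and not a number. Among these compounds, compound 3 has no single number, so no step between compound 3 and compound 4 can be read. The compounds shown leave open at what concentration any of them turns cytotoxic, and whether phenylsulfonyl in place of 2-methoxyethyl shifts that concentration.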